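A few compounds are considered here, and "the series" means these few. Any claim that something is new, unique, unknown or untested is made for them only; others in the source may bear on it.

Values so far in a functional assay on SK-MEL-2 cells (Homo sapiens) for inhibition; on this read-out lower numbers stand for stronger inhibition and higher numbers for weaker inhibition:

- compound 1 `CCOC(=O)Nc1nc(=O)n(C2O[C@H](C(=O)O)[C@@H](O)[C@H]2O)cc1F` gives 0.16 ug/mL
- compound 2 `C=CCOC(=O)Nc1nc(=O)n(C2O[C@H](C(=O)O)[C@@H](O)[C@H]2O)cc1F` gives 0.008 ug/mL
- compound 3 `O=C(Nc1nc(=O)n(C2O[C@H](C(=O)O)[C@@H](O)[C@H]2O)cc1F)Oc1ccccc1` gives 0.1 ug/mL

All three share one core and differ only in the group on an oxygen next to a carbonyl group. Compound 3 has compound 1 as its nearest neighbour, with a 1.6-fold lower number from compound 1 to compound 3 (0.20 log units; within the scatter). Its furthest neighbour is compound 2, with a 13-fold higher number from compound 2 to compound 3 (1.10 log units; beyond the scatter).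

Compound 4 `O=C(Nc1nc(=O)n(C2O[C@H](C(=O)O)[C@@H](O)[C@H]2O)cc1F)OCc1ccccc1` changes that same group: benzyl in place of phenyl on an oxygen next to a carbonyl group, benzyl in place of phenyl. Earlier swaps at this place bear on it, and they point two ways. Going from ethyl to phenyl made no clear difference, while the allyl group of compound 2 stood apart, with a 20-fold lower number from compound 1 to compound 2 (1.30 log units; beyond the scatter). So the group matters here, but three compounds give no rule for benzyl. In this assay, a small shift towards a lower number is expected, and a large one cannot be excluded. The expected result is a 1.7-fold lower number from compound 3 to compound 4 (0.22 log units; within the scatter). The estimate for compound 4 is 0.06 ug/mL, with an expected range from 0.012 ug/mL to 0.25 ug/mL.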

Compound 4, half-maximal inhibitory concentration: 0.1 ug/mL
Compound 4: the middle estimate sits 1.7-fold (0.22 log units) below what was measured; measured number inside the range.
By their numbers in this assay, from the lowest: compound 2; then compounds 3, 4 and 1 (each within the scatter of the next).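

In this assay, going from phenoxy to benzyloxy gives no change at the digits printed from compound 3 to compound 4 (within the scatter), so phenyl and benzyl read alike on this oxygen. Benzyl also stays close to ethyl, with a 1.6-fold lower number from compound 1 to compound 4 (0.20 log units; within the scatter), which places ethyl, phenyl and benzyl in one group of similar values. Allyl alone stands apart, with a 13-fold higher number from compound 2 to compound 4 (1.10 log units; beyond the scatter), so among these four groups, carrying an aromatic ring, whether as phenyl or as benzyl, does not reproduce the low number of compound 2.

Nothing shown here explains why allyl differs from the other three groups. On these data alone, it also remains open how a propyl group, or a longer chain ending in vinyl, would read on this oxygen, and so whether the vinyl end of allyl is what sets compound 2 apart.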